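This account rests on a few compounds, and the source may have more. Where it says the series, first, only, none or still open, it means among the compounds named here.

Compound 1 `COC(=O)/C=C/c1cccc(N(Cc2ccc(/C=C/c3ccccc3F)cc2)C(=O)C2CCCCC2)c1` is the reference point of the series. In an assay on isolated protein with Bile acid receptor (Homo sapiens) as the target (on this read-out lower numbers stand for an effect already at smaller amounts and higher numbers for an effect only at larger amounts of compound), compound 1 gives 64 nM, the lowest of the two numbers in hand. Compound 2 `COC(=O)/C=C/c1cccc(N(Cc2ccc(/C=C/c3ccccc3F)cc2)C(=O)NC(C)C)c1` gives 431 nM; with isopropylamino in place of cyclohexyl on a carbonyl carbon this amounts to a 6.7-fold higher number from compound 1 to compound 2 (0.83 log units; beyond the scatter). Compound 3 `COC(=O)/C=C/c1cccc(N(C)C(=O)C2CCCCC2)c1` reaches only (the limit of > 1000 nM in this assay, at which 1 of the 3 values shown sits), a limit rather than a number, so for compound 3 > 1000 nM is all that is known. Compound 4 `COC(=O)/C=C/c1cccc(N(Cc2ccc(-c3cccc(C(C)=O)c3)cc2)C(=O)C2CCCCC2)c1` differs from compound 1 in one place: 3-acetylphenyl in place of 2-(2-fluorophenyl)ethenyl on an aromatic carbon. Among the compounds with values here, no measured step touches that position: the step from compound 1 to compound 2 changes the group on the carbonyl carbon, and compound 3 retains neither the 2-(2-fluorophenyl)ethenyl group nor the ring that carries it. With the tail untested, a moderate weakening is the expectation: a 2.3-fold higher number from compound 1 to compound 4 (0.37 log units; beyond the scatter). Compound 4 is therefore estimated at 150 nM, within 50 nM to 600 nM.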

Compound 4, half-maximal effective concentration: 227 nM
Estimate against measurement, compound 4: 1.5-fold (0.18 log units) below, within the range that was stated.
By their numbers in this assay, from the lowest: compound 1; then compounds 4 and 2 (each within the scatter of the next). At a limit, above all of these: compound 3.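

The position on the aromatic carbon para to a large group does respond to substitution: 3-acetylphenyl in place of 2-(2-fluorophenyl)ethenyl gives a 3.5-fold higher number from compound 1 to compound 4 (0.55 log units; beyond the scatter). The exchange keeps the count of heavy atoms and brings in one hydrogen-bond acceptor, yet compound 4 still gives a number rather than a limit. No measurement in hand accounts for the step.

Still open, from the compounds shown here alone, is whether a plain phenyl, an amine or a carboxylic acid at this position would give a lower or higher number. Going by these compounds, the effect of the same exchange alongside the isopropylamino carbonyl of compound 2 also remains open.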